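Working notes: forced swim series, aryl change at the ring nitrogen

This account rests on a few compounds, and the source may have more. Where it says the series, first, only, none or still open, it means among the compounds named here.

compound 1 `CCC1(CCCCN2CCN(c3ccc(Cl)cc3)CC2)C(=O)Nc2ccccc21` — > 10 mg/kg
compound 2 `CCC1(CCCCN2CCN(c3ccc(F)cc3)CC2)C(=O)Nc2ccccc21` — > 10 mg/kg
compound 3 `CCC1(CCCCN2CCN(c3ccc(Cl)c(Cl)c3)CC2)C(=O)Nc2ccccc21` — not yet measured

In a functional assay on the whole organism (strain NMRI) with Mus musculus as the target, in the forced swim test, with stated times of 30 min, 4 min and 6 min (a lower number here means that less compound is needed, a higher number that more compound is needed for the effect), compound 1 gives > 10 mg/kg, and this is a limit of the assay, not a number. In this assay compound 2 gives > 10 mg/kg, again a limit. The step that the two limits leave unreadable from compound 1 to compound 2 is therefore unreadable, since both values sit at the limit of > 10 mg/kg in this assay, at which 2 of the 2 values shown sit. Compound 2 thus stands at that limit only; no number is known for it, and nothing separates it from compound 1 on the numbers shown.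

Compound 3 differs from compound 2 by 3,4-dichlorophenyl in place of 4-fluorophenyl on an amine nitrogen in a ring. Among the measured compounds shown here, the single measured step, a step that the two limits leave unreadable from compound 1 to compound 2, cannot be read, so no measured step bears on this change with a known size; the two measured compounds simply sit at the same limit. With nothing readable to build on, no step beyond the scatter is expected in this assay from compound 2 to compound 3, and the likeliest outcome is that compound 3 also reports only a limit. Compound 3 is estimated at 10 mg/kg, within 3 mg/kg to 30 mg/kg, which corresponds to an expected step of a number no higher from compound 2 to compound 3 (the limit leaves the size open).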

Compound 3, minimum effective dose: > 10 mg/kg
Compound 3 ended at the assay's limit (the forecaster's own chance of this, stated with the estimate: 75%); the middle value sits exactly at the limit.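

In this assay compound 3 gives > 10 mg/kg, a limit and not a number, so the steps among compound 1, compound 2 and compound 3 cannot be read: the limit of > 10 mg/kg in this assay, at which 3 of the 3 values shown sit.

The compounds shown leave open whether any of these groups on the amine nitrogen of the shared core gives a measurable minimum effective dose in this assay, and how 4-fluorophenyl and 3,4-dichlorophenyl would then compare.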